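Fluoro Anilide Analogue of Compound 2: Expected Cytotoxicity

This account rests on a few compounds, and the source may have more. Where it says the series, first, only, none or still open, it means among the compounds named here.

Compound 2 `COc1ccc2c(=O)c(/C=C/C(=O)Nc3ccccc3)coc2c1` gives 523000 nM in an ADME assay on HepG2 2.2.15 cells (Homo sapiens) for cytotoxicity, read by MTT assay, with stated times of 48 h and 9 days (a higher number here means that more compound is tolerated, a lower number that less compound is tolerated), the second highest of the three numbers measured; compound 3 `Cc1ccc(CNC(=O)/C=C/c2coc3cc(O)ccc3c2=O)cc1` gives 501000 nM and compound 1 `COc1ccc(CNC(=O)/C=C/c2coc3cc(O)ccc3c2=O)cc1` gives 718000 nM, both within the scatter of compound 2. For the measured compounds named here, the only measured step, a 1.4-fold lower number from compound 1 to compound 3 (0.16 log units; within the scatter), concerns methyl in place of methoxy on an aromatic carbon and stays within the scatter. Compound 4 `COc1ccc2c(=O)c(/C=C/C(=O)Nc3ccc(F)cc3)coc2c1` carries fluoro in place of hydrogen on an aromatic carbon. Going by the values given here, no measured step covers fluoro in place of hydrogen, and the one change on an aromatic carbon seen so far moved nothing beyond the scatter, so no step beyond the scatter is expected in this assay. Compound 4 is therefore estimated at 523000 nM (range 260000 nM to 1050000 nM), an expected step of no change at the digits printed from compound 2 to compound 4 (within the scatter).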

Compound 4, half-maximal cytotoxic concentration: 743000 nM
Estimate against measurement, compound 4: 1.4-fold (0.15 log units) below; low and high end bracket the measured number.
By their numbers in this assay, from the lowest: compounds 3, 2, 1 and 4 (each within the scatter of the next).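

For the compounds shown here, the phenyl to 4-fluorophenyl change gives a 1.4-fold higher number from compound 2 to compound 4 (0.15 log units; within the scatter) in this assay and is the first step read on the anilino group. At this place, para to a large group, fluoro in place of hydrogen leaves the number within the scatter, as did the different change in a 1.4-fold lower number from compound 1 to compound 3 (0.16 log units; within the scatter) on another pair. No measured property bears on this result.

From the compounds shown here alone, whether an amine or a carboxylic acid at this place would move the number beyond the scatter remains open. Fluoro on the other carbons of this ring also remains open.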